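The source may report more compounds than this note shows. Statements on the series, on what has been measured and on what is new or still open speak of the compounds shown alone.

Working notes on the series: in a functional assay on MDA-MB-231 cells (Homo sapiens) for antiproliferative activity, read by MTT assay, with a stated time of 48 h (a lower number here means a stronger inhibitor, a higher number a weaker inhibitor), compound 1 (`CN1CCN(c2ccc(-c3cc4c(N5CCN(C(=O)Nc6ccccc6)CC5)ncnc4s3)cc2)CC1`) gives 7590 nM, compound 2 (`CN1CCN(c2ccc(-c3cc4c(N5CCN(C(=O)Nc6ccccc6F)CC5)ncnc4s3)cc2)CC1`) gives 10300 nM and compound 3 (`COc1ccccc1NC(=O)N1CCN(c2ncnc3sc(-c4ccc(N5CCN(C)CC5)cc4)cc23)CC1`) gives 23200 nM. Compound 3 has the highest number of the three and is the weakest so far. The next comparison is with compound 4 (`CN1CCN(c2ccc(-c3cc4c(N5CCN(C(=O)Nc6cc(C(F)(F)F)ccc6F)CC5)ncnc4s3)cc2)CC1`), which differs as follows: 2-fluoro-5-(trifluoromethyl)phenyl in place of 2-methoxyphenyl on an amide-type nitrogen. In words, this is 2-fluoro-5-(trifluoromethyl)phenyl in place of 2-methoxyphenyl on an amide-type nitrogen. The measured steps that bear on it are a 2.3-fold higher number from compound 2 to compound 3 (0.35 log units; beyond the scatter), which is methoxy in place of fluoro and applies here in reverse, and a 3.1-fold higher number from compound 1 to compound 3 (0.49 log units; beyond the scatter). The step of a 1.4-fold higher number from compound 1 to compound 2 (0.13 log units; within the scatter) shows no change from fluoro beyond the scatter. Among the compounds with values here, no measured compound carries trifluoromethyl, so that part of the change is untested and widens the range. A modest step toward a lower number in this assay is therefore expected, similar in size to the two methoxy steps. The estimated step is a 2.3-fold lower number from compound 3 to compound 4 (0.37 log units; beyond the scatter). For compound 4 the estimate is 10000 nM, with an expected range of 4000 nM to 25000 nM.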

Compound 4, half-maximal inhibitory concentration: 9090 nM
The estimate for compound 4 lay 1.1-fold (0.04 log units) above the measured number; measured number inside the range.
By their numbers in this assay, from the lowest: compounds 1, 4 and 2 (each within the scatter of the next); then compound 3.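

In this assay, 2-fluoro-5-(trifluoromethyl)phenyl in place of 2-methoxyphenyl on the amide-type nitrogen gives a 2.6-fold lower number from compound 3 to compound 4 (0.41 log units; beyond the scatter) and so brings the series back within the scatter of the unsubstituted phenyl. Trifluoromethyl, new at this position, gives a 1.1-fold lower number from compound 2 to compound 4 (0.05 log units; within the scatter) when added to the fluoro compound, and the full replacement of phenyl gives a 1.2-fold higher number from compound 1 to compound 4 (0.08 log units; within the scatter) with both steps within the scatter, so among the four compounds only the 2-methoxyphenyl compound stands apart. No measurement shown bears on the reason for this separation.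

Open, going by these compounds, is whether the higher number stays with methoxy alone or also appears with a longer ether such as ethoxy. Also open, on these data alone, is whether an amine or a carboxylic acid on this phenyl ring would move the number beyond the scatter in either direction.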